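Stereochemical inversion within a cytotoxicity-silent bicyclic series

The source may hold more compounds than are shown below. What is called first, only, known or untested is meant among the compounds shown, and "the series" means these compounds.

Compound 1 `CCCNC(=O)[C@@H]1[C@@H]2CCC[C@H]1CN(C(=O)c1cc3sc(Br)cc3n1Cc1ccc(OC)cc1)C2` in an ADME assay on HEK-293T cells (Homo sapiens) for cytotoxicity, read by luminescence and CellTiter-Glo, with a stated time of 24 h (on this read-out higher numbers stand for lower toxicity in this test and lower numbers for higher toxicity in this test), gives only a limit, > 100000 nM. Compound 3 `CCCNC(=O)C1CC12CN(C(=O)c1cc3sc(Br)cc3n1Cc1ccc(OC)cc1)C2` also reaches only a limit in this assay, > 100000 nM. Compound 2 `CCCNC(=O)C1CCN(C(=O)c2cc(Br)cn2Cc2ccc(OC)cc2)CC1` gives a number in this assay, 55000 nM. Compound 1 thus stands at the limit of > 100000 nM in this assay, at which 2 of the 3 values shown sit, without a number of its own. Compound 4 `CCCNC(=O)[C@H]1[C@@H]2CCC[C@H]1CN(C(=O)c1cc3sc(Br)cc3n1Cc1ccc(OC)cc1)C2` is not yet measured; the two compounds have the same atoms and bonds and differ only in configuration as drawn: 1 of 3 stereo elements differ; a stereocentre at a saturated ring carbon is drawn r in compound 1 and s in compound 4 separates it from compound 1. Among the compounds with values here, no step between two measured compounds is available in this assay, so nothing measured sets a size for this change; a change of configuration alone is not expected to move the read-out beyond the scatter, and the expected step is a number no higher from compound 1 to compound 4 (the limit leaves the size open), essentially none. Compound 4 is therefore expected to give 100000 nM, between 50000 nM and 200000 nM, most likely again reported only as a limit.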

Compound 4, half-maximal cytotoxic concentration: > 100000 nM
Compound 4: only a limit was reported (the forecaster's own chance of this, stated with the estimate: 85%); the middle value lies on the limit itself.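

Compound 1 and compound 4 both end at a limit in this assay, so no step between them can be read: the limit of > 100000 nM in this assay, at which 3 of the 4 values shown sit.

From the compounds shown here alone, whether the configuration at this saturated ring carbon moves the read-out at all stays open.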